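A few compounds are considered here, and "the series" means these few. Any claim that something is new, unique, unknown or untested is made for them only; others in the source may bear on it.

Compound 3, with structure `CCN1CCc2c(c(C(C)(C)C)nn2C(=O)Nc2ccc(F)cc2F)C1`, gives 71.9% in a functional assay on the whole organism (strain Swiss albino) for inhibition, with Mus musculus as the target, in the writhing test, with a stated time of 30 min, at a dose of 100 mg/kg; a higher number here means more inhibition at the dose given (going by the name of the read-out), a lower number less inhibition. Among the measured compounds shown here, of the three numbers measured so far this one lies within the scatter of both others: compound 1, `CCN1CCc2c(c(C(C)(C)C)nn2C(=O)Nc2ccc(Br)cc2)C1`, gives 72.8%, and the step of a number 0.9 percentage points lower from compound 1 to compound 3 (within the scatter); compound 2, `CCN1CCc2c(c(C(C)(C)C)nn2C(=O)Nc2cc(C)ccc2C)C1`, gives 63.1%, and the step of a number 8.8 percentage points higher from compound 2 to compound 3 (within the scatter). The remaining measured step, a number 9.7 percentage points lower from compound 1 to compound 2 (within the scatter), also stays within the scatter. All three steps exchange the aryl group on the amide-type nitrogen while the shared core is kept, and none of them moves the inhibition beyond the scatter.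

Compound 4, `CCN1CCc2c(c(C(C)(C)C)nn2C(=O)Nc2cc(C)ccc2F)C1`, has not yet been measured. Its difference from compound 3 is 2-fluoro-5-methylphenyl in place of 2,4-difluorophenyl on an amide-type nitrogen. Because the comparable exchanges a number 0.9 percentage points lower from compound 1 to compound 3 (within the scatter) and a number 8.8 percentage points higher from compound 2 to compound 3 (within the scatter) both stayed within the scatter, no step beyond the scatter is expected for compound 4, and the expected step of a number 2.9 percentage points lower from compound 3 to compound 4 (within the scatter) reflects this. Compound 4 is therefore estimated at 69%, with a range from 57% to 80%.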

Compound 4, a percentage reported as inhibition, in the whole organism at one dose (the size of the read-out at that dose, not a potency): 17.5%
Compound 4: the middle estimate sits 51.5 percentage points above what was measured; the measured number lies below the stated range.
By their numbers in this assay, from the lowest: compound 4; then compounds 2, 3 and 1 (each within the scatter of the next).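

Among the compounds shown here, until this result, every exchange of the aryl group on the amide-type nitrogen had stayed within the scatter, but in this assay this position proves sensitive, with a number 54.4 percentage points lower from compound 3 to compound 4 (beyond the scatter) and a number 55.3 percentage points lower from compound 1 to compound 4 (beyond the scatter) both large. The closest comparison shows that a single exchange is enough: fluoro in place of methyl on an aromatic carbon gives a number 45.6 percentage points lower from compound 2 to compound 4 (beyond the scatter) and turns 2,5-dimethylphenyl into 2-fluoro-5-methylphenyl. Neither substituent alone goes with the low number, since compound 3 also carries fluoro and compound 2 also carries methyl, and nothing available bears on what lies behind this loss.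

The compounds shown leave open whether the low inhibition belongs to this one pairing of fluoro and methyl. A chloro or methoxy group in place of the methyl of compound 4 could settle whether the inhibition returns.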